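From methoxy to azido at the assay limit

The source may report more compounds than this note shows. Statements on the series, on what has been measured and on what is new or still open speak of the compounds shown alone.

Measured in a functional assay on KYSE-450 cells (Homo sapiens) for inhibition, read by CCK-8 assay, with a stated time of 48 h; on this read-out higher numbers stand for weaker inhibition and lower numbers for stronger inhibition:
- Compound 1 `COc1ccc(CN(C(=O)CSC(=S)N2CCc3ccccc3C2)c2cc(OC)c(OC)c(OC)c2)cc1` gives > 20000 nM as a limit
- Compound 2 `COc1ccc(CN(C(=O)CSC(=S)N2CCN(C(=O)OC(C)(C)C)CC2)c2cc(OC)c(OC)c(OC)c2)cc1OC` gives > 20000 nM as a limit

Neither compound has an exact number in this assay. Compound 2 stands at the limit of > 20000 nM in this assay, at which 2 of the 2 values shown sit, and therefore gives a limit, not a number.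

Compound 3 `COc1ccc(CN(C(=O)CSC(=S)N2CCN(C(=O)OC(C)(C)C)CC2)c2cc(OC)c(OC)c(OC)c2)cc1N=[N+]=[N-]` has not yet been measured. It keeps the rest of compound 2 and carries azido in place of methoxy on an aromatic carbon. This turns 3,4-dimethoxybenzyl into 3-azido-4-methoxybenzyl, with the azido group ortho to a methoxy group and meta to a large group.

Within the data shown here, the measured compounds provide no step that sizes this change. The likeliest outcome is that compound 3 stays near the limit, possibly reported only as one, although a clear gain in inhibition cannot be excluded. This expectation rests on compound 2 with > 20000 nM as its limit. The expected at least 1.3-fold lower number from compound 2 to compound 3 (0.12 log units; that floor lies within the scatter) is small and points toward stronger inhibition. For compound 3 the estimated value is 15000 nM with an expected range from 2000 nM to 40000 nM in this assay.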

Compound 3, half-maximal inhibitory concentration: 840 nM
Beside the measured number, compound 3's estimate is 18-fold (1.25 log units) above it; the whole stated range lies above it.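

In this assay, turning 3,4-dimethoxybenzyl into 3-azido-4-methoxybenzyl gives an at least 23-fold lower number from compound 2 to compound 3 (1.37 log units; beyond the scatter). This single exchange of methoxy for azido, on an aromatic carbon and with the rest of the molecule unchanged, moves the read-out from a limit to an exact number, so this position can clearly affect inhibition of these cells, which the two earlier limits could not show. The size of the step is only a floor, not an exact figure, because compound 2 gives a limit and not a number: the limit of > 20000 nM in this assay, at which 2 of the 3 values shown sit.

On these data alone, what stays open is whether this gain belongs to azido itself or would also appear with another group at the same place, such as an amine, a nitrile or a chlorine atom. The compounds shown also leave open whether azido would have a similar effect at another carbon of this aromatic ring, or in the different setting of compound 1, whose own value is likewise only a limit.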